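Swapping a cyclohexyl for a pentyl on an acylhydrazone

The source may hold more compounds than are shown below. What is called first, only, known or untested is meant among the compounds shown, and "the series" means these compounds.

Measured so far:
- Compound 1, `O=C(N/N=C/C1CCCCC1)c1ccc(O[C@@H]2O[C@H](CO)[C@@H](O)[C@H](O)[C@H]2O)cc1`, in a functional assay on MDA-MB-231 cells (Homo sapiens) for inhibition, read by MTT assay, with a stated time of 24 h, tested at 100 uM (a lower number here means less inhibition, a higher number more inhibition at the concentration tested (going by the name of the read-out)), gives 0.88%.
- Compound 2, `CC(=O)OC[C@H]1O[C@@H](Oc2ccc(-c3nnc(-c4ccc([N+](=O)[O-])cc4)o3)cc2)[C@H](OC(C)=O)[C@@H](OC(C)=O)[C@@H]1OC(C)=O`, in this assay gives 58%.
- Compound 3, `CC(=O)OC[C@H]1O[C@@H](Oc2ccc(-c3nnc(C4CCCCC4)o3)cc2)[C@H](OC(C)=O)[C@@H](OC(C)=O)[C@@H]1OC(C)=O`, in this assay gives 11.6%.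

Of the three measured compounds, compound 1 stands lowest, with both others beyond the scatter above it; the nearest is compound 3, the furthest compound 2. Compound 4, `CCCCC/C=N/NC(=O)c1ccc(O[C@@H]2O[C@H](CO)[C@@H](O)[C@H](O)[C@H]2O)cc1`, has not yet been measured. It differs from compound 1 in one place: pentyl in place of cyclohexyl on a carbon with a double bond to nitrogen.

Among the measured compounds shown here, only one measured step is available: a number 46.4 percentage points lower from compound 2 to compound 3 (beyond the scatter). For the measured compounds named here, that step exchanges an aromatic group for a cyclohexyl on a different core, so it does not directly test a cyclohexyl against a pentyl, and no measured pair does. It is therefore hard to predict a direction, and a reasonable expectation is that the change from a ring to a chain of similar size leaves the number close to where compound 1 sits. The step is expected to be a number 2.1 percentage points higher from compound 1 to compound 4 (within the scatter), that is, within the scatter. Compound 4 is estimated to give 3%, with a range from 0% to 14%.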

Compound 4, a percentage reported as inhibition, at one concentration (the size of the read-out at that concentration, not a potency): 11%
The estimate for compound 4 lay 8 percentage points below the measured number; low and high end bracket the measured number.
By their numbers in this assay, from the lowest: compound 1; then compounds 4 and 3 (each within the scatter of the next); then compound 2.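

On the carbon with a double bond to nitrogen, replacing the cyclohexyl ring with an open pentyl chain gives, in this assay, a number 10.1 percentage points higher from compound 1 to compound 4 (beyond the scatter). Among the compounds shown here, this is the first direct comparison of a ring with a chain at this position, and it shows that the read-out responds to this change, although the step is modest; the earlier step, a number 46.4 percentage points lower from compound 2 to compound 3 (beyond the scatter), replaced an aromatic group on a different core and could not show this. Nothing available here accounts for the higher number with the pentyl chain, so the result records what happens without explaining it.

The compounds shown leave open whether a longer chain, such as octyl, would move the number further, or whether a chain ending in an amine or a carboxylic acid would change it in either direction. For the compounds shown here, they also leave open whether pentyl in place of cyclohexyl would give a similar step on a different core, such as the one carried by compound 3.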